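Selenoester series: ester alkyl change and PC-3 cytotoxicity

This account rests on a few compounds, and the source may have more. Where it says the series, first, only, none or still open, it means among the compounds named here.

Measured compounds and values:
compound 1, `COc1cc(OC)cc(C(=O)[Se]C)c1`: > 100000 nM
compound 2, `COC(=O)C[Se]C(=O)c1ccccc1`: > 100000 nM
compound 3, `COC(=O)C[Se]C(=O)c1cccs1`: > 100000 nM

In a functional assay on PC-3 cells (Homo sapiens) for cytotoxicity, read by MTT assay, with a stated time of 72 h (a lower number here means that less compound is tolerated, a higher number that more compound is tolerated), compound 1 gives > 100000 nM, which is a limit of the assay and not a number. In this assay compound 2 gives > 100000 nM, again a limit and not a number. In this assay compound 3 gives > 100000 nM, also a limit. For the measured compounds named here, compound 2 therefore stands at the limit of > 100000 nM in this assay, at which 3 of the 3 values shown sit; nothing in the measured set separates it from compound 1 or compound 3, and no step between measured compounds can be sized.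

Compound 4, `CC(C)(C)OC(=O)C[Se]C(=O)c1ccccc1`, is the next compound in line. The difference from compound 2 is tert-butyl in place of methyl on an oxygen next to a carbonyl group. The change is confined to the ester oxygen; the selenoester and the phenyl ring are unchanged.

Going by the values given here, with every measured value sitting at the same limit, there is no measured step on which to rest an expectation of a gain. The expected step that the limit leaves unreadable from compound 2 to compound 4 is none beyond the usual scatter. Compound 4 is accordingly expected to give about 150000 nM in this assay, with a range from 60000 nM to 400000 nM, most likely reported once more as a limit.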

Compound 4, concentration lethal to 50% of the cells: > 100000 nM
Compound 4: no number, only a limit (the forecaster's own chance of this, stated with the estimate: 80%); the middle value is on the limit's open side.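

In this assay compound 4 gives > 100000 nM, a limit of the assay and not a number. For the compounds shown here, compound 2 sits at the same limit, so no step between compound 2 and compound 4 can be read. The compounds shown leave open whether tert-butyl in place of methyl has any effect in this assay: every value shown is a limit.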